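Replacing the methyl(methylsulfonyl)amino group of compound 3

The source may report more compounds than this note shows. Statements on the series, on what has been measured and on what is new or still open speak of the compounds shown alone.

Of the compounds shown here, three have been measured in a functional assay on blood for inhibition of Polyunsaturated fatty acid 5-lipoxygenase (Homo sapiens); on this read-out lower numbers stand for stronger inhibition and higher numbers for weaker inhibition. Compound 1 `COC1(c2cc(Sc3ccc(/C(C)=N/O)cc3)cc(F)c2C)CCOCC1` gives 20 nM. Compound 2 `Cn1c(=O)ccc2ccc(CSc3cc(C4(C)COC(C)(C)O4)cs3)cc21` gives 6930 nM. Compound 3 `CN(c1ccc(Sc2cc(C3(C)COC(C)(C)O3)cs2)cc1)S(C)(=O)=O` gives 160 nM, which places it second highest of the three numbers: compound 1 is its nearest neighbour with a lower number, and that gap lies beyond the usual scatter, while compound 2 stands furthest with a much higher number, again beyond the scatter. Going by the values given here, no two of these share a core, so no single-point step among measured compounds is available.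

Compound 4 `CO/N=C(\C)c1ccc(Sc2cc(C3(C)COC(C)(C)O3)cs2)cc1` differs from compound 3 in one place: a group of 5 heavy atoms (3 carbon, 1 nitrogen, 1 oxygen; no ring) in place of a group of 6 heavy atoms (2 carbon, 1 nitrogen, 2 oxygen, 1 sulfur; no ring), on an aromatic carbon. Among the compounds with values here, with no measured step of this kind, the expectation rests on compound 1, whose related side chain on a different core gives 20 nM in this assay. On that basis compound 4 is expected to come in somewhat lower than compound 3. The expected step is small and directed toward a lower number, a 2.3-fold lower number from compound 3 to compound 4 (0.36 log units; beyond the scatter), and may well fall within the scatter. Compound 4 is estimated at 70 nM, with a range from 18 nM to 280 nM.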

Compound 4, half-maximal inhibitory concentration: 270 nM
The estimate for compound 4 lay 3.9-fold (0.59 log units) below the measured number, within the range that was stated.
By their numbers in this assay, from the lowest: compound 1; then compounds 3 and 4 (each within the scatter of the next); then compound 2.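

Going by these compounds alone, on the shared core of compound 3 and compound 4, this is the first change at the aromatic carbon para to a large group that can be read directly. In this assay, putting the group of 5 heavy atoms in place of methyl(methylsulfonyl)amino is read as a 1.7-fold higher number from compound 3 to compound 4 (0.23 log units; within the scatter) and so leaves the number within the usual scatter, even though the sulfur atom and one double bond outside aromatic rings are gone and the count of hydrogen-bond acceptors stays the same. This single step therefore shows that, on this core, the sulfonyl-bearing group can be exchanged for this ring-free group with no change beyond the scatter, but nothing measured here explains that outcome.

What the compounds shown leave open is how the number would respond at this same carbon to a nitrile, a carboxylic acid, an amine or a longer chain. Also open, on these data alone, is whether the exchange would read the same way on a different core, since this one step comes from a single matched pair.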